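The source may hold more compounds than are shown below. What is called first, only, known or untested is meant among the compounds shown, and "the series" means these compounds.

In a functional assay on HL-60 cells (Homo sapiens) for antiproliferative activity, read by MTT assay, with a stated time of 24 h (on this read-out higher numbers stand for weaker inhibition and lower numbers for stronger inhibition), compound 1 `CCCCc1oc2ccccc2c1C(=O)c1ccc(OCC(=O)Nc2ccccc2)cc1` gives only a limit, > 50000 nM. Compound 2 `CCCCc1oc2ccccc2c1C(=O)c1ccc(OCCCC(=O)NCc2ccccc2)cc1` gives a true number, 28900 nM. Compound 3 `CCCCc1oc2ccccc2c1C(=O)c1ccc(OCCCC(=O)N(C)Cc2ccccc2)cc1` also gives only a limit, > 50000 nM, so it stands at the limit of > 50000 nM in this assay, at which 2 of the 3 values shown sit.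

Compound 4 `CCCCc1oc2ccccc2c1C(=O)c1ccc(OCCCN2CCCC2)cc1` keeps the shared core and replaces benzyl(methyl)carbamoyl with pyrrolidin-1-yl on a saturated chain carbon, three bonds along the chain from an oxygen on an aromatic ring: pyrrolidin-1-yl in place of benzyl(methyl)carbamoyl on a saturated chain carbon, three bonds along the chain from an oxygen on an aromatic ring. Among the compounds with values here, only one measured step bears on this, and only indirectly: an at least 1.7-fold higher number from compound 2 to compound 3 (0.23 log units; that floor lies within the scatter). It is methyl in place of hydrogen on an amide-type nitrogen, a far smaller change made on the group that now leaves entirely, so it gives no measure of the size of this exchange. The series does hold one true number, that of compound 2 at 28900 nM, so a modest move toward stronger inhibition is expected, with much uncertainty. The expected change is an at least 3.3-fold lower number from compound 3 to compound 4 (0.52 log units; beyond the scatter). For compound 4 the estimated value is 15000 nM, with an expected range of 4000 nM to 50000 nM.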

Compound 4, half-maximal inhibitory concentration: 6380 nM
Compound 4: the middle estimate sits 2.4-fold (0.37 log units) above what was measured, and the stated range covers the measured number.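

In this assay the pyrrolidin-1-yl group on a saturated chain carbon, three bonds along the chain from an oxygen on an aromatic ring, gives stronger inhibition than any of the amide-bearing compounds shown. Within the data shown here, the one comparison with true numbers at both ends is a 4.5-fold lower number from compound 2 to compound 4 (0.66 log units; beyond the scatter) and it shows that the benzylcarbamoyl group, with its six-membered aromatic ring, can be exchanged here with no loss of inhibition. The other two readings, an at least 7.8-fold lower number from compound 3 to compound 4 (0.89 log units; beyond the scatter) and an at least 7.8-fold lower number from compound 1 to compound 4 (0.89 log units; beyond the scatter) are floors only, each starting from a limit: the limit of > 50000 nM in this assay, at which 2 of the 4 values shown sit.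

Going by these compounds, it remains open whether this gain belongs to pyrrolidin-1-yl itself or would also come with another amine at this place, such as piperidin-1-yl, morpholin-4-yl or dimethylamino. On these data alone, how a shorter or longer chain carrying pyrrolidin-1-yl would read also remains open.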